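The source may hold more compounds than are shown below. What is called first, only, known or untested is meant among the compounds shown, and "the series" means these compounds.

Measured so far:
- compound 1, `Cc1cc(N2CC[C@@H](C)[C@@H](N(C)c3ncnc4[nH]ccc34)C2)n2nc(SCc3ccc(Cl)cc3)nc2n1`, 16000 nM
- compound 2, `Cc1cc(N2CC[C@@H](C)[C@@H](N(C)c3ncnc4[nH]ccc34)C2)n2nc(SCCc3ccccc3)nc2n1`, 6190 nM

For the measured compounds named here, in a functional assay on MGC-803 cells (Homo sapiens) for inhibition, read by MTT assay, with a stated time of 72 h (on this read-out higher numbers stand for weaker inhibition and lower numbers for stronger inhibition), compound 2 stands with the lowest of the two numbers measured, and the only neighbour is compound 1, reached by a 2.6-fold lower number from compound 1 to compound 2 (0.41 log units; beyond the scatter). Compound 3, `C#CSc1nc2nc(C)cc(N3CC[C@@H](C)[C@@H](N(C)c4ncnc5[nH]ccc45)C3)n2n1`, is the next compound to be measured in this assay. Its change from compound 2 is ethynyl in place of phenethyl on a sulfur. Going by the values given here, the one measured step concerned the group beyond the sulfur, and it shifted the number by a modest amount, but it kept an aromatic ring in place, whereas in compound 3 the ring is gone. Among the compounds with values here, no measured step shows what removing the ring does. Given that loss, compound 3 is expected to land at a higher number, estimated at 14000 nM, with a range from 3500 nM to 56000 nM. The expected step is a 2.3-fold higher number from compound 2 to compound 3 (0.35 log units; beyond the scatter).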

Compound 3, half-maximal inhibitory concentration: 18100 nM
Estimate against measurement, compound 3: 1.3-fold (0.11 log units) below; the range from low to high includes it.
By their numbers in this assay, from the lowest: compound 2; then compounds 1 and 3 (each within the scatter of the next).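

In this assay, exchanging the phenethyl on the sulfur for the much smaller, ring-free ethynyl gives a 2.9-fold higher number from compound 2 to compound 3 (0.47 log units; beyond the scatter), the first sign that removing the aromatic ring from this group can raise the number. Yet an aromatic ring alone does not secure a lower number, since the ethynyl and 4-chlorobenzyl groups cannot be told apart here, with a 1.1-fold higher number from compound 1 to compound 3 (0.05 log units; within the scatter), and only compound 2 stands apart from the other two. Nothing available explains these differences.

Still open, as far as these compounds go, is whether a plain ethyl or methyl on the sulfur would match ethynyl, which would show whether the triple bond itself matters. Also open, from the compounds shown here alone, is whether a longer chain such as phenylpropyl, or an amine on the phenethyl ring, would lower the number further.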